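Triazole nitrogen substituent swap in a HeLa cell assay

The source may report more compounds than this note shows. Statements on the series, on what has been measured and on what is new or still open speak of the compounds shown alone.

Measured compounds:
Compound 1 `CCOC(=O)C1=Cc2ccccc2OC1(OCc1cn(CC(=O)NC2CCCCC2)nn1)C(F)(F)F`: 11400 nM
Compound 2 `CCOC(=O)C1=Cc2ccccc2OC1(OCc1cn(-c2ccc(F)c(Cl)c2)nn1)C(F)(F)F`: 22700 nM

Two compounds share the core and differ only in the group on the aromatic nitrogen of the triazole. In a functional assay on HeLa cells (Homo sapiens) for inhibition, read by MTT assay, with a stated time of 24 h (a lower number here means a stronger inhibitor, a higher number a weaker inhibitor), compound 2 gives 22700 nM, the highest of the two numbers shown, while compound 1 gives 11400 nM. Within the data shown here, the only measured step, a 2.0-fold higher number from compound 1 to compound 2 (0.30 log units; within the scatter), lies within the scatter, so the two values show no real order between them.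

Compound 3 `CCOC(=O)C1=Cc2ccccc2OC1(OCc1cn(CC(=O)Nc2cccc(F)c2)nn1)C(F)(F)F` is not yet measured. It differs from compound 2 in one place: ((3-fluorophenyl)carbamoyl)methyl in place of 3-chloro-4-fluorophenyl on an aromatic nitrogen. The entering group carries a carbamoylmethyl linker like that of compound 1, with a 3-fluorophenyl rather than a cyclohexyl on the amide nitrogen. Among the measured compounds shown here, the one step that bears on this change, a 2.0-fold higher number from compound 1 to compound 2 (0.30 log units; within the scatter), was small, so no step beyond the scatter is expected in this assay in either direction. Compound 3 is therefore expected to fall near both measured values, at about 14000 nM, with a range from 5000 nM to 40000 nM; this estimate means a step of a 1.6-fold lower number from compound 2 to compound 3 (0.21 log units; within the scatter).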

Compound 3, half-maximal inhibitory concentration: > 150000 nM
Compound 3: only a limit was reported; the forecaster's own chance of this, stated with the estimate: 10%; middle value at least 10-fold (1.02 log units) from the limit.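

Compound 3 is reported in this assay only as a limit, not as a number: the limit of > 150000 nM in this assay, at which 1 of the 3 values shown sits.

Even read as a limit, the result shows that the group on the aromatic nitrogen of the triazole can move the number beyond the scatter, which the earlier pair did not show: the change gives an at least 6.6-fold higher number from compound 2 to compound 3 (0.82 log units; beyond the scatter). It also shows that the carbamoylmethyl linker does not by itself set the number, since exchanging only the group on the amide nitrogen, 3-fluorophenyl in place of cyclohexyl, gives an at least 13-fold higher number from compound 1 to compound 3 (1.11 log units; beyond the scatter).

Going by these compounds, the true size of both steps stays open, as each rests on a limit, and so does the question of whether the aromatic ring on the amide nitrogen or the fluorine on it goes with the higher number. An unsubstituted phenyl or a cyclopentyl on the amide nitrogen, or a longer chain in place of the linker, would bear on what the three compounds leave unsettled.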